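Swapping Ethylsulfanyl for Fluoro: Expected Cytotoxicity

This account rests on a few compounds, and the source may have more. Where it says the series, first, only, none or still open, it means among the compounds named here.

Compound 1, `CCSc1ccc(-c2nccc3[nH]c(C(C)(C)O)cc23)cc1`: 17200 nM
Compound 2, `CC(C)(O)c1cc2c(-c3cc(C(F)(F)F)cc(C(F)(F)F)c3)nccc2[nH]1`: 59800 nM
Compound 3, `CC(C)(O)c1cc2c(-c3ccc4ccccc4c3)nccc2[nH]1`: 22500 nM

Of the compounds shown here, three built on one shared core have been measured in an ADME assay on U2OS cells (Homo sapiens) for cytotoxicity; a lower number here means that less compound is tolerated, a higher number that more compound is tolerated. Among the three numbers, compound 1 shows the lowest. Compound 3 comes nearest, and the gap between compound 1 and compound 3 lies within the usual scatter of repeated measurements, so the two are best read as alike. Compound 2 sits furthest away, and that gap does lie beyond the scatter.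

The next compound, compound 4, `CC(C)(O)c1cc2c(-c3ccc(F)cc3)nccc2[nH]1`, differs from compound 1 in one place:

fluoro in place of ethylsulfanyl on an aromatic carbon

For the measured compounds named here, no two of the measured compounds differ in only one spot, so there is no measured step to lean on; the three known values merely span a modest range. Going by the values given here, for this change, no step clearly beyond the scatter is expected, with a slight upward lean at most. The expected step is a 1.5-fold higher number from compound 1 to compound 4 (0.16 log units; within the scatter). Compound 4 is therefore expected to give about 25000 nM in this assay, within an estimated range from 10000 nM to 70000 nM.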

Compound 4, half-maximal cytotoxic concentration: 93600 nM
Compound 4: middle estimate off by 3.7-fold (0.57 log units), on the low side; measured number above the stated range.
By their numbers in this assay, from the lowest: compounds 1 and 3 (each within the scatter of the next); then compounds 2 and 4 (each within the scatter of the next).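

Replacing ethylsulfanyl with fluoro, on an aromatic carbon para to a large group, gives a 5.4-fold higher number from compound 1 to compound 4 (0.74 log units; beyond the scatter) in this assay at this position. For the compounds shown here, this is the first single-place comparison in the set, and it shows that the group held at this carbon can shift the tolerated concentration by more than the usual scatter. Nothing available explains why this swap has such an effect.

Going by these compounds alone, with only one swap at this position, it remains unclear whether the step reflects the departure of ethylsulfanyl, the arrival of fluoro, or both. Methylsulfanyl, chloro or an amine at the same carbon could show whether the number stays near that of compound 1, stays near that of compound 4 or falls somewhere in between.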